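The compounds below may be only part of what the source reports. "The series", "measured", "known", "first", "only" and "open" are said of these compounds alone.

Compound 1 `CCCn1c(=O)n(CC(=O)O)c(=O)c2[nH]cnc21` gives only a limit of the assay, > 200000 nM, in an assay on Cerebral cortex for binding affinity to adenosine receptor A1 (Cavia porcellus), read by radioligand binding; a higher number here means a weaker inhibitor, a lower number a stronger inhibitor.
Compound 2 `CCCn1c(=O)n(CCC(N)=O)c(=O)c2[nH]cnc21` gives 31500 nM in this assay.
Compound 3 `CCCn1c(=O)n(CCCN(C)C)c(=O)c2[nH]cnc21` gives 43200 nM in this assay.

Compound 3 holds the highest of the two plain numbers, yet a 1.4-fold higher number from compound 2 to compound 3 (0.14 log units; within the scatter), so compounds 2 and 3 cannot be told apart. Compound 4 `CCCn1c(=O)n(CCCO)c(=O)c2[nH]cnc21` differs from compound 3 by hydroxy in place of dimethylamino on a saturated chain carbon, three bonds along the chain from an aromatic nitrogen. Of the measured steps, an at least 6.3-fold lower number from compound 1 to compound 2 (0.80 log units; beyond the scatter) and an at least 4.6-fold lower number from compound 1 to compound 3 (0.66 log units; beyond the scatter) show that replacing carboxy by either a carbamoyl-bearing or an amine-bearing chain gives a lower number, while a 1.4-fold higher number from compound 2 to compound 3 (0.14 log units; within the scatter) shows the two chains behaving alike. A hydroxy-bearing chain is therefore expected to land near compound 3, with no step beyond the scatter: compound 4 is estimated at 40000 nM, between 15000 nM and 120000 nM, meaning a 1.1-fold lower number from compound 3 to compound 4 (0.03 log units; within the scatter).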

Compound 4, inhibition constant: 12000 nM
Estimate against measurement, compound 4: 3.3-fold (0.52 log units) above; measured number outside the range, below it.
By their numbers in this assay, from the lowest: compound 4; then compounds 2 and 3 (each within the scatter of the next). At a limit, above all of these: compound 1.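

At this chain end, the groups can be told apart after all: compounds 2 and 3 stayed within the scatter of each other, but hydroxy gives a 3.6-fold lower number from compound 3 to compound 4 (0.56 log units; beyond the scatter) and a 2.6-fold lower number from compound 2 to compound 4 (0.42 log units; beyond the scatter) in this assay. Against the carboxy chain the gap is larger, an at least 16-fold lower number from compound 1 to compound 4 (1.22 log units; beyond the scatter). That step has an open end, since compound 1 gives only a limit and not a number: the limit of > 200000 nM in this assay, at which 1 of the 4 values shown sits.

Still open, as far as these compounds go, is whether a methoxy group in place of the hydroxy would keep the lower number. A longer chain carrying the hydroxy is equally untested here.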